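Urea series: chloro for trifluoromethyl, cytotoxicity outlook

The compounds below may be only part of what the source reports. "The series", "measured", "known", "first", "only" and "open" are said of these compounds alone.

Two ureas on a shared core have been measured in an ADME assay on Raji cells (Homo sapiens) for cytotoxicity, with a stated time of 72 h; a lower number here means that less compound is needed, a higher number that more compound is needed for the effect. Compound 1 `Cc1cc(NC(=O)Nc2ccc(Cl)c(Cl)c2)c2ccccc2n1` gives 10000 nM. Compound 2 `Cc1cc(NC(=O)Nc2ccc(C(F)(F)F)cc2)c2ccccc2n1` gives 23000 nM, which is the higher of the two numbers; compound 1 stands below it by more than the usual scatter, so on the numbers shown compound 2 needs the larger amount of material for the effect.

The next compound, compound 3 `Cc1cc(NC(=O)Nc2ccc(Cl)cc2)c2ccccc2n1`, differs from compound 2 in one place: chloro in place of trifluoromethyl on an aromatic carbon. The change sits on an aromatic carbon of a six-membered aromatic ring of carbon only. Among the compounds with values here, no step between measured compounds covers this exact exchange, so the expectation rests only on what compounds 1 and 2 show.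

Because compound 1 gives 10000 nM while compound 2 gives 23000 nM, a compound carrying a single chloro on that ring is expected to fall between the two, and the step from compound 2 to compound 3 is expected to be a modest lowering, a 1.5-fold lower number from compound 2 to compound 3 (0.19 log units; within the scatter), at the edge of the scatter. Compound 3 is therefore estimated at 15000 nM in this assay, with a range from 6000 nM to 40000 nM.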

Compound 3, half-maximal effective concentration: > 25000 nM
Compound 3: no number, only a limit; the forecaster's own chance of this, stated with the estimate: 20%; at least 1.6-fold (0.22 log units) between middle value and limit.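

In this assay compound 3 gives a limit of the assay and not a number: the limit of > 25000 nM in this assay, at which 1 of the 3 values shown sits.

Chloro in place of trifluoromethyl, on an aromatic carbon para to a large group, gives an at least 1.0-fold higher number from compound 2 to compound 3 (0.03 log units; that floor lies within the scatter), so the floor of this exchange does not set the two compounds apart, and the exchange shows no lowering of the number. Hydrogen in place of chloro on an aromatic carbon gives an at least 2.5-fold higher number from compound 1 to compound 3 (0.39 log units; beyond the scatter), the first single-place change in the series that is read as beyond the scatter, and it ties the lower number of compound 1 to the chloro that compound 3 lacks.

From the compounds shown here alone, how far compound 3 lies past its limit stays unknown, so the true size of both steps remains open, and only their floors can be read. Also open, going by these compounds, is whether the number at this ring position responds to groups of another kind, such as an amine or a carboxylic acid in place of chloro or trifluoromethyl, and whether the chloro that separates compound 1 from compound 3 acts in the same way alongside them.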